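A phenyl swap at the limit: compound 3 to compound 4

The source may hold more compounds than are shown below. What is called first, only, known or untested is meant among the compounds shown, and "the series" means these compounds.

In a functional assay on HepG2 cells (Homo sapiens) for cytotoxicity, read by MTT assay, with a stated time of 72 h (on this read-out lower numbers stand for stronger inhibition and higher numbers for weaker inhibition), compound 1 `CNC(=O)c1cc(Oc2ccc(C3=NNC(c4ccc(F)cc4)C3)cc2)ccn1` gives 5280 nM and compound 2 `CNC(=O)c1cc(Oc2ccc(C3=NNC(c4cccc(Cl)c4Cl)C3)cc2)ccn1` gives 4990 nM. Compound 3 `CNC(=O)c1cc(Oc2ccc(C3=NN(C(N)=S)C(c4ccc(F)cc4)C3)cc2)ccn1` reads > 50000 nM, which is a limit of the assay and not a number. Compound 4 `CNC(=O)c1cc(Oc2ccc(C3=NN(C(N)=S)C(c4cccc(Cl)c4Cl)C3)cc2)ccn1` differs from it by 2,3-dichlorophenyl in place of 4-fluorophenyl on a saturated ring carbon, with 2,3-dichlorophenyl in place of 4-fluorophenyl on a saturated ring carbon. Within the data shown here, two measured steps bear on this. The same exchange, with hydrogen on the amine nitrogen in the ring, is a 1.1-fold lower number from compound 1 to compound 2 (0.02 log units; within the scatter). Placing the group of 3 heavy atoms on that nitrogen is an at least 9.4-fold higher number from compound 1 to compound 3 (0.97 log units; beyond the scatter). Going by a 1.1-fold lower number from compound 1 to compound 2 (0.02 log units; within the scatter), no step beyond the scatter is expected in this assay. The expected step is a number no higher from compound 3 to compound 4 (the limit leaves the size open). For compound 4 the estimate is 50000 nM, with an expected range of 20000 nM to 100000 nM.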

Compound 4, half-maximal inhibitory concentration: 1890 nM
Compound 4: the middle estimate sits 26-fold (1.42 log units) above what was measured; measured number outside the range, below it.
By their numbers in this assay, from the lowest: compound 4; then compounds 2 and 1 (each within the scatter of the next). At a limit, above all of these: compound 3.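

In this assay, 2,3-dichlorophenyl in place of 4-fluorophenyl, a step within the scatter with hydrogen on the ring nitrogen, gives an at least 26-fold lower number from compound 3 to compound 4 (1.42 log units; beyond the scatter) once the group of 3 heavy atoms sits on that nitrogen: the same change on two cores in this assay, a 1.1-fold lower number (0.02 log units; within the scatter) from compound 1 to compound 2 and an at least 26-fold lower number (1.42 log units; beyond the scatter) from compound 3 to compound 4, at least 25-fold (1.39 log units) apart, beyond the scatter of two such steps. Compound 3 stands at a limit of the assay, > 50000 nM, so this step has a bound and no exact size. Placing that group on the nitrogen also changes direction with 2,3-dichlorophenyl present, giving a 2.6-fold lower number from compound 2 to compound 4 (0.42 log units; beyond the scatter): the same change on two cores in this assay, an at least 9.4-fold higher number (0.97 log units; beyond the scatter) from compound 1 to compound 3 and a 2.6-fold lower number (0.42 log units; beyond the scatter) from compound 2 to compound 4, at least 25-fold (1.39 log units) apart, beyond the scatter of two such steps. The compounds shown leave open whether an acetyl group on that nitrogen would pair with 2,3-dichlorophenyl in the same way, and whether an unsubstituted phenyl would pair with the group of 3 heavy atoms as 2,3-dichlorophenyl does.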